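This account rests on a few compounds, and the source may have more. Where it says the series, first, only, none or still open, it means among the compounds named here.

Measured in a functional assay on A549 cells (Homo sapiens) for inhibition, read by MTT assay, with a stated time of 24 h; on this read-out higher numbers stand for weaker inhibition of growth and lower numbers for stronger inhibition of growth:
- compound 1 `COc1cc(C(=O)n2c(-c3cn(C)c4ccccc34)nc3ccccc32)cc(OC)c1OC`: 2600 nM
- compound 2 `COc1ccc2c(c1)c(-c1nc3ccccc3n1C(=O)c1cc(OC)c(OC)c(OC)c1)cn2C`: 2400 nM
- compound 3 `COc1ccc(C(=O)n2c(-c3cn(C)c4ccc(Br)cc34)nc3ccccc32)cc1OC`: 3400 nM

At 3400 nM, compound 3 lies within the scatter of both compound 1 and compound 2, so the three values cannot be ranked. Compound 4 `COc1cc(C(=O)n2c(-c3cn(C)c4ccc(Br)cc34)nc3ccccc32)cc(OC)c1OC` follows from compound 3 by one change: methoxy in place of hydrogen on an aromatic carbon. For the measured compounds named here, only one measured step bears on it, and it is the same kind of replacement: a 1.1-fold lower number from compound 1 to compound 2 (0.03 log units; within the scatter). That methoxy enters elsewhere in the structure, so the step is only a loose guide. Even so, it gives no reason to expect a shift beyond the scatter in this assay, and no direction can be drawn from it. The expected change is small, a 1.2-fold lower number from compound 3 to compound 4 (0.08 log units; within the scatter), which stays within the scatter. For compound 4 the estimated value is 2800 nM, with an expected range of 1400 nM to 5400 nM.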

Compound 4, concentration for 50% growth inhibition: 3000 nM
For compound 4 the middle estimate is 1.1-fold (0.03 log units) below the measured one, and the stated range covers the measured number.
By their numbers in this assay, from the lowest: compounds 2, 1, 4 and 3 (each within the scatter of the next).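

In this assay, the methoxy at this place, ortho to a methoxy group and meta to a large group, now has a direct reading on the bromo-bearing core, and it shifts nothing beyond the scatter: a 1.1-fold lower number from compound 3 to compound 4 (0.05 log units; within the scatter). Bromo also gets its first single-change readings, with a 1.2-fold higher number from compound 1 to compound 4 (0.06 log units; within the scatter) for bromo in place of hydrogen and a 1.3-fold higher number from compound 2 to compound 4 (0.10 log units; within the scatter) for bromo in place of methoxy, and neither step leaves the scatter. The methoxy change comes out alike on the two cores: the same change on two cores in this assay, a 1.1-fold lower number (0.03 log units; within the scatter) from compound 1 to compound 2 and a 1.1-fold lower number (0.05 log units; within the scatter) from compound 3 to compound 4, 1.0-fold (0.02 log units) apart, within the scatter of two such steps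

The compounds shown carry only hydrogen or methoxy at this place, so it remains open whether an amine, a hydroxyl or a longer chain such as ethoxy would move the number beyond the scatter. Since every step here stays within the scatter, they also do not show which part of the structure governs growth inhibition.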